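The source may report more compounds than this note shows. Statements on the series, on what has been measured and on what is new or still open speak of the compounds shown alone.

Three compounds set the scene for this step. Compound 1 `C[C@H]1CCC/C=C/[C@H]2CC[C@H](O)[C@H](CC(=O)O1)O2` offers no number in a functional assay on A-375 cells (Homo sapiens) for inhibition, read by MTT assay, with a stated time of 48 h (a lower number here means a stronger inhibitor, a higher number a weaker inhibitor), where its entry reads "not determined" (no result reported). Compound 2 `CO[C@H]1C=C[C@H]2C/C=C\C[C@H](c3ccc(Br)cc3)OC(=O)C[C@@H]1O2` gives 5450 nM in this assay, and compound 3 `COc1ccc(CO[C@H]2C=C[C@H]3C/C=C\C[C@H](c4ccc(F)cc4)OC(=O)C[C@@H]2O3)cc1` gives 4760 nM. These two values lie within the scatter of each other, so compound 2 stands level with compound 3 and no order can be drawn between them.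

Compound 4 `CO[C@H]1C=C[C@H]2C/C=C\C[C@H](c3ccc(-c4ccccc4C(F)(F)F)cc3)OC(=O)C[C@@H]1O2` has not yet been measured. It departs from compound 2 at a single place: 2-(trifluoromethyl)phenyl in place of bromo on an aromatic carbon. In words, 2-(trifluoromethyl)phenyl stands in place of bromo on an aromatic carbon, para to a large group.

Among the compounds with values here, no measured step shows what a change at this place does in this assay. Within the data shown here, the only guide is a comparison with compound 2, from which compound 3 differs in several places. Compound 3 gives 4760 nM, close to the value of compound 2. A step that stays within the scatter is therefore expected, leaning if anything toward a lower number. The expected step is a 1.4-fold lower number from compound 2 to compound 4 (0.16 log units; within the scatter). For compound 4 the estimated value is 3800 nM, with an expected range from 1500 nM to 10000 nM.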

Compound 4, half-maximal inhibitory concentration: 9640 nM
Beside the measured number, compound 4's estimate is 2.5-fold (0.40 log units) below it, within the range that was stated.
By their numbers in this assay, from the lowest: compounds 3, 2 and 4 (each within the scatter of the next, the first and the last beyond it).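

In this assay, within the data shown here, the exchange of bromo for 2-(trifluoromethyl)phenyl gives a 1.8-fold higher number from compound 2 to compound 4 (0.25 log units; within the scatter), the first step that can be read at this place on the aromatic ring. It shows that a single bromine atom can give way to a group of 10 heavy atoms carrying a six-membered aromatic ring of carbon only, and compound 4 still stands level with compound 2 within the scatter of this measurement. The compounds shown offer no measurement that accounts for this result.

What the compounds leave open is how far this level result extends, as a single step at this place cannot show whether other groups would also stay within the scatter of compound 2, such as an amine, a carboxylic acid or a longer chain. They also leave open what the trifluoromethyl group itself contributes to the number of compound 4, as a plain phenyl group at the same place does not appear among them for comparison.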